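The source may hold more compounds than are shown below. What is called first, only, known or untested is meant among the compounds shown, and "the series" means these compounds.

Measured compounds in an assay on HEK cells for antagonist activity at transient receptor potential cation channel subfamily V member 1 (Homo sapiens), read by FLIPR; on this read-out higher numbers stand for weaker inhibition and lower numbers for stronger inhibition:
compound 1 `O=C(NCc1ccc(C(F)(F)F)nc1N1CCCCC1)Nc1cccc2[nH]c(=O)ccc12`, 0.75 nM
compound 2 `CCCN(CCC)c1nc(C(F)(F)F)ccc1CNC(=O)Nc1cccc2[nH]c(=O)ccc12`, 5.21 nM
compound 3 `CCCCOc1nc(C(F)(F)F)ccc1CNC(=O)Nc1cccc2[nH]c(=O)ccc12`, 4 nM

Compound 1 stands lowest of the three in this assay; the nearest step is a 5.3-fold higher number from compound 1 to compound 3 (0.73 log units; beyond the scatter), the furthest is a 6.9-fold higher number from compound 1 to compound 2 (0.84 log units; beyond the scatter), both modest and beyond the scatter. Compound 4 `CCCCCOc1nc(C(F)(F)F)ccc1CNC(=O)Nc1cccc2[nH]c(=O)ccc12` differs from compound 1 by pentyloxy in place of piperidin-1-yl on an aromatic carbon. The two replacements of the piperidin-1-yl ring by an open chain already measured both bear on this: a 6.9-fold higher number from compound 1 to compound 2 (0.84 log units; beyond the scatter) and a 5.3-fold higher number from compound 1 to compound 3 (0.73 log units; beyond the scatter). Between those two open-chain compounds the step of a 1.3-fold lower number from compound 2 to compound 3 (0.11 log units; within the scatter) lies within the scatter, so the pentyloxy of compound 4 is expected to land near them, an upward step from compound 1 of about a 6.7-fold higher number from compound 1 to compound 4 (0.82 log units; beyond the scatter). For compound 4 the expected value is 5 nM, with a range from 1.5 nM to 16 nM.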

Compound 4, half-maximal inhibitory concentration: 2.72 nM
Compound 4: middle estimate off by 1.8-fold (0.26 log units), on the high side; low and high end bracket the measured number.
By their numbers in this assay, from the lowest: compound 1; then compounds 4, 3 and 2 (each within the scatter of the next).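

In this assay, pentyloxy on this aromatic carbon next to the ring nitrogen again stands apart from the piperidin-1-yl of compound 1 (a 3.6-fold higher number from compound 1 to compound 4 (0.56 log units; beyond the scatter)), making it the third open chain with a higher number and with no listed exception. Among the open chains, the added chain carbon (a 1.5-fold lower number from compound 3 to compound 4 (0.17 log units; within the scatter)) and the exchange of dipropylamino for pentyloxy (a 1.9-fold lower number from compound 2 to compound 4 (0.28 log units; within the scatter)) both stay within the scatter, so neither chain length nor the oxygen or nitrogen link separates these compounds. No available data explain why the piperidin-1-yl ring differs from the open chains.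

Going by these compounds, whether a pyrrolidine or morpholine ring would match piperidin-1-yl remains open. So does whether a shorter chain such as ethoxy would stay with the open chains.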